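A few compounds are considered here, and "the series" means these few. Any claim that something is new, unique, unknown or untested is made for them only; others in the source may bear on it.

Values so far in a functional assay on HT cells (Homo sapiens) for antiproliferative activity, read by fluorescence, with a stated time of 72 h (a lower number here means a stronger inhibitor of growth, a higher number a weaker inhibitor of growth), are as follows
- compound 1 `CC(C)c1n[nH]c2c(NCc3ccc(-c4ccccn4)cc3)nc(SCC(O)CO)nc12` gives 21 nM
- compound 2 `CC(C)c1n[nH]c2c(NCc3ccc(-c4ccccn4)cc3)nc(SCC(N)CN)nc12` gives 480 nM
- compound 3 `CC(C)c1n[nH]c2c(NCc3ccc(-c4ccccn4)cc3)nc(SCCO)nc12` gives 48 nM

Compound 3 holds the middle place of the three numbers. Its nearest neighbour is compound 1, and a 2.3-fold higher number from compound 1 to compound 3 (0.36 log units; beyond the scatter) is the gap. Its furthest neighbour is compound 2, and a 10-fold lower number from compound 2 to compound 3 (1.00 log units; beyond the scatter) is that gap.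

The next compound is compound 4 `CC(C)c1n[nH]c2c(NCc3ccc(-c4ccccn4)cc3)nc(SCC3CNC(=O)O3)nc12`, with this change from compound 3: 2-oxo-1,3-oxazolidin-5-yl in place of hydroxymethyl on a saturated chain carbon bound to a sulfur on a saturated chain carbon bound to a sulfur. In other words, (2-hydroxyethyl)sulfanyl gives way to ((2-oxo-1,3-oxazolidin-5-yl)methyl)sulfanyl.

Two measured steps alter this same chain. The modest one, a 2.3-fold higher number from compound 1 to compound 3 (0.36 log units; beyond the scatter), concerns a hydroxymethyl group. The large one, a 23-fold higher number from compound 1 to compound 2 (1.36 log units; beyond the scatter), shows that this chain can move the number substantially. Neither step puts a ring on the chain, so both are only a loose guide. No step beyond the scatter is therefore expected, though a weaker result is the likelier risk, and the estimated step is a 1.3-fold higher number from compound 3 to compound 4 (0.10 log units; within the scatter) in this assay with wide uncertainty.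

For compound 4 the expected value is 60 nM within an estimated range of 20 nM to 200 nM overall.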

Compound 4, concentration for 50% growth inhibition: 80 nM
Beside the measured number, compound 4's estimate is 1.3-fold (0.12 log units) below it, within the range that was stated.
By their numbers in this assay, from the lowest: compound 1; then compounds 3 and 4 (each within the scatter of the next); then compound 2.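

In this assay, a ring can stand on this chain: a 1.7-fold higher number from compound 3 to compound 4 (0.22 log units; within the scatter) lies within the scatter, so 2-oxo-1,3-oxazolidin-5-yl cannot be told apart from hydroxymethyl on a saturated chain carbon bound to a sulfur. Set against 1,2-dihydroxyethyl, the same ring gives a 3.8-fold higher number from compound 1 to compound 4 (0.58 log units; beyond the scatter), and set against 1,2-diaminoethyl it gives a 6.0-fold lower number from compound 2 to compound 4 (0.78 log units; beyond the scatter), so the ring lands with the hydroxyl-bearing chains, nearer the hydroxymethyl result than the 1,2-diaminoethyl one. No measurement available here accounts for these differences.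

The compounds shown leave open whether the whole ring matters or only its carbonyl or its amide hydrogen. Also open, on these data alone, is how a carboxylic acid, a longer chain ending in hydroxyl, or a single amine in place of 1,2-diaminoethyl would read in this assay.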